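The source may report more compounds than this note shows. Statements on the series, on what has been measured and on what is new or still open speak of the compounds shown alone.

Values in a functional assay on A549 cells (Homo sapiens) for cytotoxicity, read by MTT assay, with a stated time of 24 h; a higher number here means a weaker inhibitor, a lower number a stronger inhibitor:
- compound 1 `C=CCn1c(=O)c(/C=C/C(=O)/C=C(O)/C=C/c2ccc(O)c(OC)c2)cc2ccccc21`: 31300 nM
- compound 2 `C#CCn1c(=O)c(/C=C/C(=O)/C=C(O)/C=C/c2ccc(O)c(OC)c2)cc2ccccc21`: 21300 nM
- compound 3 `C#CCn1c(=O)c(/C=C/C(=O)/C=C(O)/C=C/c2ccc(O)c(OC)c2)cc2cc(OC)ccc21`: not yet measured

Among the compounds with values here, only two values are available, so the position of compound 2 is easily stated. Compound 2 gives 21300 nM, within the scatter of compound 1. The next structural change runs from compound 2 to compound 3: methoxy in place of hydrogen on an aromatic carbon. In words, this is methoxy in place of hydrogen on an aromatic carbon.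

Within the data shown here, only one measured step exists, a 1.5-fold lower number from compound 1 to compound 2 (0.17 log units; within the scatter). It is ethynyl in place of vinyl on a saturated chain carbon bound to an aromatic nitrogen, so it concerns a different place in the structure. Among the measured compounds shown here, no measurement yet covers a change on the aromatic carbon, and the size and direction of its effect remain open. With no evidence for a shift, the expectation stays close to the value of compound 2, 21300 nM. The expected result is a 1.1-fold lower number from compound 2 to compound 3 (0.03 log units; within the scatter), with no step beyond the scatter. In this assay, the estimated value for compound 3 is 20000 nM, with an expected range of 9000 nM to 45000 nM.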

Compound 3, half-maximal inhibitory concentration: 20600 nM
Compound 3: middle estimate off by 1.0-fold (0.01 log units), on the low side; measured number inside the range.
By their numbers in this assay, from the lowest: compounds 3, 2 and 1 (each within the scatter of the next).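

In this assay, the step on the aromatic carbon is a 1.0-fold lower number from compound 2 to compound 3 (0.01 log units; within the scatter) and lies within the scatter, so this assay does not separate hydrogen from methoxy at this position of compound 2. Within the data shown here, this is the first reading from an aromatic carbon of the six-membered aromatic ring of carbon only, part of a fused or bridged system of two rings, whereas the earlier step concerned only the saturated chain carbon bound to an aromatic nitrogen. With the ethynyl compounds held constant in that chain, adding methoxy, with its two heavy atoms and one hydrogen-bond acceptor, leaves compound 3 within the scatter of compound 2, and no measurement here explains this result.

A single substituent at one aromatic carbon cannot show whether the rest of this ring behaves the same way, so a carboxylic acid or an amine on the same carbon remains an open case. Going by these compounds, it also remains open whether methoxy would read the same alongside vinyl instead of ethynyl, and whether any change on this ring gives a step beyond the scatter.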